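The source may report more compounds than this note shows. Statements on the series, on what has been measured and on what is new or still open speak of the compounds shown alone.

Within the data shown here, compound 2 `O=C(O)C[C@@H]1CCCN1c1ccc(Oc2ccc(Cl)cc2Cl)cc1` is the one member of this set that gives a number in a functional assay on cells for agonist activity at Free fatty acid receptor 1 (Mus musculus), read by FLIPR and calcium flux, with a stated time of 100 s; on this read-out higher numbers stand for an effect only at larger amounts of compound and lower numbers for an effect already at smaller amounts: in that assay compound 2 gives 3200 nM. Compound 1 `Cc1ccccc1COc1ccc(N2CCC[C@H]2CC(=O)O)cc1C` is reported only as a limit of the assay, > 33000 nM. Compound 3 `CN(C)c1cccc(Oc2ccc(N3CCC[C@H]3CC(=O)O)cc2)c1` likewise reaches only a limit, > 33000 nM. So compound 2 stands alone with a measured value, and what the other two show is the limit of > 33000 nM in this assay, at which 2 of the 3 values shown sit. Compound 4 `Cc1ccc(Oc2ccc(N3CCC[C@H]3CC(=O)O)cc2)cc1` has not yet been measured. It differs from compound 2 in one place: 4-methylphenyl in place of 2,4-dichlorophenyl on an oxygen on an aromatic ring. Among the measured compounds shown here, no step between measured compounds is available to guide this change, so its size must be guessed. The writer nonetheless expects a loss of potency, a step of a 3.1-fold higher number from compound 2 to compound 4 (0.49 log units; beyond the scatter), beyond the usual scatter, because of the limit of > 33000 nM in this assay, at which 2 of the 3 values shown sit. For compound 4 the expected half-maximal effective concentration is 10000 nM, within a range of 3500 nM to 33000 nM. A result given only as a limit would not surprise.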

Compound 4, half-maximal effective concentration: > 33000 nM
Compound 4 ended at the assay's limit; the forecaster's own chance of this, stated with the estimate: 40%; middle value at least 3.3-fold (0.51 log units) from the limit.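

In this assay, among these compounds, placing 4-methylphenyl in place of 2,4-dichlorophenyl on an oxygen on an aromatic ring gives the first step that can be read at this position: an at least 10-fold higher number from compound 2 to compound 4 (1.01 log units; beyond the scatter), a large change from a single replacement. Compound 4 gives > 33000 nM, which is a limit of the assay and not a number, so the step marks only a minimum size. Compound 2 thus remains the one compound shown with a measured value, and this one change from it already reaches the limit shared by most of the set: the limit of > 33000 nM in this assay, at which 3 of the 4 values shown sit.

The compounds shown leave open whether both chlorines are needed, since a phenyl carrying a single chlorine does not appear among them. They also leave open how an unsubstituted phenyl on this oxygen would compare with compound 2.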